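Nitrogen substituent exchange: propargyl to tert-butoxycarbonyl

The source may report more compounds than this note shows. Statements on the series, on what has been measured and on what is new or still open speak of the compounds shown alone.

Measured so far in an assay on isolated protein for inhibition of Aromatase (Homo sapiens), read by fluorescence, using NADPH, with a stated time of 30 min, tested at 50 uM; on this read-out higher numbers stand for more inhibition at the one concentration tested (going by the name of the read-out) and lower numbers for less inhibition:
compound 1, `C#CCn1c(-c2ccccc2)cc2ccccc21`, 26.3%
compound 2, `Cn1c(-c2ccc(Cl)c(Cl)c2)cc2ccccc21`, 20%
compound 3, `Cn1c(-c2ccc(Cl)c(Cl)c2)cc2cc([N+](=O)[O-])ccc21`, 34%

Compound 1 sits within the usual scatter of both compound 2 and compound 3, so the three numbers cannot be ranked against one another. Among the measured compounds shown here, the one step that exceeds the scatter runs between compound 2 and compound 3: a number 14 percentage points higher from compound 2 to compound 3 (beyond the scatter). It concerns a substituent on an aromatic carbon and says nothing about the ring nitrogen.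

Compound 4, `CC(C)(C)OC(=O)n1c(-c2ccccc2)cc2ccccc21`, is not yet measured in this assay. It differs from compound 1 in one place: tert-butoxycarbonyl in place of propargyl on an aromatic nitrogen. For the measured compounds named here, no measured pair differs at the ring nitrogen, so no step bears on this change. With nothing to point either way, the expectation for compound 4 is a step of a number 0.3 percentage points lower from compound 1 to compound 4 (within the scatter), which means no change beyond the scatter. Compound 4 is therefore expected to give about 26% in this assay, with a range from 12% to 40%.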

Compound 4, a percentage reported as inhibition, at one concentration (the size of the read-out at that concentration, not a potency): 11.9%
The estimate for compound 4 lay 14.1 percentage points above the measured number, and the stated range ends above it.
By their numbers in this assay, from the lowest: compounds 4, 2, 1 and 3 (each within the scatter of the next, the first and the last beyond it).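

The ring nitrogen now has a measured step of its own: tert-butoxycarbonyl in place of propargyl on the aromatic nitrogen gives a number 14.4 percentage points lower from compound 1 to compound 4 (beyond the scatter) in this assay, so the read-out is sensitive to the substituent at this position. The exchange changes several things at once, going from 3 to 7 heavy atoms, from 0 to 2 hydrogen-bond acceptors, and from a triple bond to a double bond outside the aromatic rings, and this single pair cannot separate them. No measurement at hand explains the lower number.

From the compounds shown here alone, it remains open whether the step follows from the arrival of tert-butoxycarbonyl or the departure of propargyl, which an acetyl group or a longer alkyl chain on the same nitrogen of the core of compound 1 could help to separate. Going by these compounds, it also remains open whether the same exchange would give a similar step on the core of compound 3, which carries a nitro group.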